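Aryl swap on the carbonyl carbon of a furyl thiadiazine core

This account rests on a few compounds, and the source may have more. Where it says the series, first, only, none or still open, it means among the compounds named here.

Measured compounds:
compound 1 `COc1cc(C(=O)C2Sc3nnc(-c4cc(OC)c(OC)c(OC)c4)n3NC2c2ccco2)cc(OC)c1OC` with 52200 nM
compound 2 `COc1cc(-c2nnc3n2NC(c2ccco2)C(C(=O)c2ccc(Cl)cc2)S3)cc(OC)c1OC` with 67800 nM
compound 3 `COc1cc(-c2nnc3n2NC(c2ccco2)C(C(=O)c2cccc(Br)c2)S3)cc(OC)c1OC` with 63900 nM

In a functional assay on PC-3 cells (Homo sapiens) for cytotoxicity, read by MTT assay, with a stated time of 48 h (on this read-out higher numbers stand for weaker inhibition and lower numbers for stronger inhibition), compound 3 stands second highest of the three numbers. Its nearest neighbour is compound 2, a gap of a 1.1-fold lower number from compound 2 to compound 3 (0.03 log units; within the scatter), and its furthest is compound 1, a gap of a 1.2-fold higher number from compound 1 to compound 3 (0.09 log units; within the scatter). Both gaps lie within the scatter, so the three numbers cannot be told apart.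

Compound 4 `COc1cc(-c2nnc3n2NC(c2ccco2)C(C(=O)c2ccc(-c4ccccc4)cc2)S3)cc(OC)c1OC` has not yet been measured. It differs from compound 3 in one place: 4-phenylphenyl in place of 3-bromophenyl on a carbonyl carbon.

Within the data shown here, the steps that bear on this change are the earlier aryl swaps on the same carbonyl carbon. From compound 1 to compound 2 the number moved by a 1.3-fold higher number from compound 1 to compound 2 (0.11 log units; within the scatter), from compound 1 to compound 3 by a 1.2-fold higher number from compound 1 to compound 3 (0.09 log units; within the scatter), and from compound 2 to compound 3 by a 1.1-fold lower number from compound 2 to compound 3 (0.03 log units; within the scatter). Every one of them stayed within the scatter, whether the aryl group carried three methoxy groups, a chlorine or a bromine.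

On that basis compound 4 is expected to show no step beyond the scatter, that is a 1.1-fold lower number from compound 3 to compound 4 (0.03 log units; within the scatter). The estimate for compound 4 in this assay is 60000 nM, with an expected range from 30000 nM to 120000 nM.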

Compound 4, half-maximal inhibitory concentration: 45900 nM
Compound 4: the middle estimate sits 1.3-fold (0.12 log units) above what was measured; low and high end bracket the measured number.
By their numbers in this assay, from the lowest: compounds 4, 1, 3 and 2 (each within the scatter of the next).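

In this assay, the group on the carbonyl carbon grows from 7 heavy atoms and one aromatic ring in 3-bromophenyl to 12 heavy atoms and 2 aromatic rings in 4-phenylphenyl, yet a 1.4-fold lower number from compound 3 to compound 4 (0.14 log units; within the scatter) stays within the scatter. The comparisons with the other two compounds also stay within the scatter, with a 1.5-fold lower number from compound 2 to compound 4 (0.17 log units; within the scatter) for phenyl in place of chloro on an aromatic carbon and a 1.1-fold lower number from compound 1 to compound 4 (0.06 log units; within the scatter) for 4-phenylphenyl in place of 3,4,5-trimethoxyphenyl, so adding a second aromatic ring still leaves all four compounds indistinguishable in this read-out. Nothing available explains this flat result or shows how these compounds act on the cells.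

The compounds shown leave open whether this position would respond to a group of a different kind, such as a phenyl ring carrying an amine or a carboxylic acid, or a longer alkyl chain in place of the aromatic ring. They also leave open whether changing the furyl group or the trimethoxyphenyl group on the shared core would move the number beyond the scatter.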